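Swapping the aryl ring of a chalcone amide

This account rests on a few compounds, and the source may have more. Where it says the series, first, only, none or still open, it means among the compounds named here.

For the measured compounds named here, compound 1 `O=C(COc1ccc(C(=O)/C=C/c2ccccc2Cl)cc1)N[C@H]1CCOC1=O` is the only member of this set with a numerical result: in a functional assay on MCF7 cells (Homo sapiens) for antiproliferative activity, read by MTT assay, with a stated time of 72 h (on this read-out higher numbers stand for weaker inhibition and lower numbers for stronger inhibition), compound 1 gives 17400 nM. Compound 2 `O=C(CNc1ccc(Cl)cc1Cl)N[C@H]1CCOC1=O` reaches only the limit of this assay, with compound 2 at > 64000 nM. Compound 3 `O=C(CNc1ccccc1)N[C@H]1CCOC1=O` likewise stops at the limit, compound 3 giving > 64000 nM; this is the limit of > 64000 nM in this assay, at which 2 of the 3 values shown sit. Compound 4 `O=C(COc1ccc(C(=O)/C=C/c2ccc(F)c(F)c2)cc1)N[C@H]1CCOC1=O` differs from compound 1 in one place: 3,4-difluorophenyl in place of 2-chlorophenyl on a double-bonded chain carbon bound to a double-bonded chain carbon. No measured pair in this set differs in a single place, so no step is shown for guidance. The change is expected to move this assay little, no further than the usual scatter, with the step from compound 1 to compound 4 estimated at a 1.1-fold lower number from compound 1 to compound 4 (0.04 log units; within the scatter). Compound 4 is therefore expected to give about 16000 nM, within 5000 nM to 50000 nM.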

Compound 4, half-maximal inhibitory concentration: > 64000 nM
Compound 4: only a limit was reported (the forecaster's own chance of this, stated with the estimate: 15%); middle value at least 4.0-fold (0.60 log units) away from the limit.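

For the compounds shown here, with the activity of compound 1 as the reference, this is the first readable step in the set, and it shows that the aryl group on a double-bonded chain carbon bound to a double-bonded chain carbon is not a silent position. Replacing 2-chlorophenyl with 3,4-difluorophenyl gives an at least 3.6-fold higher number from compound 1 to compound 4 (0.56 log units; beyond the scatter) in this assay. The result for compound 4 is a limit, not a number: the limit of > 64000 nM in this assay, at which 3 of the 4 values shown sit.

The compounds shown leave open whether a plain phenyl, a 4-methoxyphenyl or a 4-chlorophenyl at this position would hold the activity of compound 1. They also leave open how much the chlorine alone contributes.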